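A few compounds are considered here, and "the series" means these few. Any claim that something is new, unique, unknown or untested is made for them only; others in the source may bear on it.

Compound 1 `COc1ccc(NC(=O)CCCCCCNC(=O)C(O)(O)C(F)(F)F)cc1` is the anchor of this set. Within the data shown here, in a functional assay on HCT-116 cells (Homo sapiens) for inhibition, read by colorimetric assay, with a stated time of 3 days (a lower number here means a stronger inhibitor, a higher number a weaker inhibitor), compound 1 gives 4520 nM, the only outright number among the three values recorded there. Compound 2 `O=C(CCCCCCC(O)C(F)(F)F)Nc1ccccc1` reaches only a limit of the assay, > 40000 nM, rather than a number. Compound 3 `C/C(=N\O)C(=O)NCCCCC(=O)Nc1ccccc1` likewise stops at a limit, > 100000 nM. Among the measured compounds shown here, no pair of measured compounds differs in a single place, so no step is known from measurement. Compound 4 `O=C(CCCCCCNC(=O)C(O)(O)C(F)(F)F)Nc1ccc(F)cc1` differs from compound 1 by fluoro in place of methoxy on an aromatic carbon. Since nothing measured speaks to this change, compound 4 is expected to sit close to compound 1, with an estimated step of a 1.3-fold higher number from compound 1 to compound 4 (0.12 log units; within the scatter) that lies within or only slightly beyond the usual scatter. Compound 4 is therefore estimated at 6000 nM, within a range from 2000 nM to 20000 nM.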

Compound 4, half-maximal inhibitory concentration: 7570 nM
For compound 4 the middle estimate is 1.3-fold (0.10 log units) below the measured one; the range from low to high includes it.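

Read in this assay, the swap of fluoro for methoxy on this aromatic carbon, para to a large group, gives a 1.7-fold higher number from compound 1 to compound 4 (0.22 log units; within the scatter), the first step in the set known from measurement. Compound 4 thus stays at an outright number rather than a limit, so the methoxy group is not required at this position for a measurable value. Nothing shown accounts for this step. Still open, from the compounds shown here alone, is how an amine, a carboxylic acid or a chloro group would read at this position, and what a longer chain would do.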